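The compounds below may be only part of what the source reports. "The series", "measured", "known", "first", "only" and "open" are said of these compounds alone.

Measured in a functional assay on the whole organism with Mus musculus as the target, in the rotarod test; a higher number here means that more compound is needed for the effect, a lower number that less compound is needed:
- compound 1 `CN(C)CC(=O)NCC(=O)N(C)c1ccc(Cl)cc1C(=O)c1ccccc1Cl`: 26 mg/kg
- compound 2 `CCCCC(=O)NCC(=O)N(C)c1ccc(Cl)cc1C(=O)c1ccccc1Cl`: 90 mg/kg
- compound 3 `CN(C(=O)CNC(=O)c1ccccc1)c1ccc(Cl)cc1C(=O)c1ccccc1Cl`: value is a limit of the assay, > 100 mg/kg

Compound 1 stands lowest of the two numbers available; its nearest neighbour is compound 2, with a 3.5-fold higher number from compound 1 to compound 2 (0.54 log units; beyond the scatter). Compound 3 sits at the limit of > 100 mg/kg in this assay, at which 1 of the 3 values shown sits, so the step from compound 1 to compound 3 is only bounded, an at least 3.8-fold higher number from compound 1 to compound 3 (0.58 log units; beyond the scatter). Between compound 2 and compound 3 the step is an at least 1.1-fold higher number from compound 2 to compound 3 (0.04 log units; that floor lies within the scatter).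

Compound 4 `CCN(CC)CC(=O)NCC(=O)N(C)c1ccc(Cl)cc1C(=O)c1ccccc1Cl` differs from compound 1 by diethylamino in place of dimethylamino on a saturated chain carbon bound to a carbonyl carbon.

The two measured steps away from compound 1 both remove the dimethylamino group entirely, one putting propyl in its place and one putting phenyl in place of (dimethylamino)methyl, and both raise the number modestly or more. Neither step tests what compound 4 does, which keeps an amine on the saturated chain carbon bound to the carbonyl carbon and only enlarges it from dimethylamino to diethylamino. In this assay the expectation is therefore a step no larger than the scatter, leaning if anything toward a slightly higher number: a 1.3-fold higher number from compound 1 to compound 4 (0.13 log units; within the scatter). Compound 4 is estimated at 35 mg/kg, with a range from 15 mg/kg to 80 mg/kg.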

Compound 4, dose for half-maximal effect: 34 mg/kg
Compound 4: middle estimate off by 1.0-fold (0.01 log units), on the high side, within the range that was stated.
By their numbers in this assay, from the lowest: compounds 1 and 4 (each within the scatter of the next); then compound 2. At a limit, above all of these: compound 3.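

Enlarging the amine on the saturated chain carbon bound to a carbonyl carbon, with dimethylamino giving way to diethylamino, leaves the number in this assay unresolved, a 1.3-fold higher number from compound 1 to compound 4 (0.12 log units; within the scatter), so this change at this position does not separate the two amines. The earlier steps only compared dimethylamino with groups that carry no amine at all; a second amine now gives the same contrast with the propyl end, a 2.6-fold lower number from compound 2 to compound 4 (0.42 log units; beyond the scatter), and among the four compounds shown none goes against the two amine compounds having the lower numbers. With phenyl on the carbonyl carbon the step is only bounded, an at least 2.9-fold lower number from compound 3 to compound 4 (0.46 log units; beyond the scatter), since the value of that compound is a limit of the assay: the limit of > 100 mg/kg in this assay, at which 1 of the 4 values shown sits.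

Among these compounds, only two open-chain dialkylamino groups are covered here, so it remains open whether a cyclic amine such as piperidine or morpholine, a primary amine, or a longer dipropylamino group would stay with compound 1 and compound 4. Also open, from the compounds shown here alone, is whether a longer chain between the amine and the carbonyl carbon would keep the number in this assay where these two compounds stand.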